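The compounds below may be only part of what the source reports. "The series", "measured", "known", "first", "only" and "open" are said of these compounds alone.

Compound 3, `COc1ccc(C(N)=O)cc1S(=O)(=O)Nc1cccnc1`, is a sulfonamide linking a methoxy-bearing benzene ring to a pyridine. For the measured compounds named here, in an assay on isolated protein for inhibition of alkaline phosphatase, tissue-nonspecific isozyme (Homo sapiens) (a lower number here means a stronger inhibitor, a higher number a weaker inhibitor), compound 3 gives 1490 nM, the second highest of the three numbers known. Its nearest neighbour is compound 1, `COc1cc(Cl)ccc1S(=O)(=O)Nc1cccnc1`, which in this assay gives 4170 nM; furthest away is compound 2, `COc1ccc(Cl)cc1S(=O)(=O)Nc1cncc(C(=O)Nc2ccccc2)c1`, which gives 310 nM. Compound 4, `COc1ccc(Br)cc1S(=O)(=O)Nc1cccnc1`, keeps the core of compound 3 and changes one group: bromo in place of carbamoyl on an aromatic carbon. Going by the values given here, no pair of measured compounds differs in this way alone, so the size of the step is uncertain. The carbamoyl group that leaves carries a hydrogen-bond donor and acceptor, and compound 4 is expected to be somewhat weaker, with an estimated step of a 1.9-fold higher number from compound 3 to compound 4 (0.27 log units; within the scatter), giving an expected value of 2800 nM within a range of 900 nM to 9000 nM.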

Compound 4, half-maximal inhibitory concentration: 43 nM
For compound 4 the middle estimate is 65-fold (1.81 log units) above the measured one; measured number outside the range, below it.
By their numbers in this assay, from the lowest: compound 4; then compound 2; then compound 3; then compound 1.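

Bromo in place of carbamoyl at this place, para to a methoxy group, gives a 35-fold lower number from compound 3 to compound 4 (1.54 log units; beyond the scatter) in this assay. For the compounds shown here, this is the first step between compounds that differ in one place only, and it shows that the group here can change the reading greatly on this core. No measurement available accounts for the size of this step.

Going by these compounds, whether the gain comes from bromo itself or from losing carbamoyl stays open. So does how a methyl, a nitrile or a carboxylic acid would read at this place.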